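Swapping the oxazole for a benzene ring on the amide nitrogen

The compounds below may be only part of what the source reports. "The series", "measured", "known", "first", "only" and "open" are said of these compounds alone.

Compound 1: `Cc1ccc(OCC(=O)N(Cc2cccs2)c2ncco2)cc1` — 0.3 nM
Compound 2: `CCN(Cc1cccs1)C(=O)c1cc2cc(C)ccc2n1C` — "not active" (no number reported)
Compound 3: `Cc1ccc(OCC(=O)N(Cc2cccs2)c2ccccc2)cc1` — not yet measured

Of the compounds shown here, two have been tested in an assay on HEK293 cells for agonist activity at transient receptor potential cation channel subfamily M member 8 (Homo sapiens), read by fluorescence and calcium flux, with a stated time of 15 min; a lower number here means that less compound is needed, a higher number that more compound is needed for the effect. Among the compounds with values here, compound 1 gives 0.3 nM, the only number in the set, so it stands alone as the reference point. Compound 2, which has a different core, is reported only as "not active" (no number reported), and it shares no single point of difference with compound 1, so nothing can be read from the pair beyond what the two entries say.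

Compound 3 keeps the whole of compound 1 except at one place: phenyl in place of 1,3-oxazol-2-yl on an amide-type nitrogen. The group that leaves carries two hydrogen-bond acceptors and a second heteroatom; the group that enters carries none. Within the data shown here, with no comparable pair measured, the size of this step is unknown, and the expectation rests only on the change itself. A step in this assay of a 10-fold higher number from compound 1 to compound 3 (1.00 log units; beyond the scatter) is expected, in the direction of more compound being needed, and beyond the usual scatter. Compound 3 is therefore estimated at 3 nM, within a range from 0.4 nM to 30 nM.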

Compound 3, half-maximal effective concentration: 23 nM
Estimate against measurement, compound 3: 7.7-fold (0.88 log units) below; the measured number falls inside the stated range.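

Replacing 1,3-oxazol-2-yl with phenyl on the amide-type nitrogen gives, in this assay, a 77-fold higher number from compound 1 to compound 3 (1.88 log units; beyond the scatter). Within the data shown here, this is the only direct reading at this position, and it shows that the group placed here strongly affects how much compound is needed. Compound 3 still gives a number, 23 nM, so a six-membered ring of carbon only on this nitrogen does not abolish the effect, but nothing measured here shows which difference between the two rings matters: the hetero atoms, the hydrogen-bond acceptors or the ring size.

The compounds shown leave open where a thiazole ring, a pyridine ring or a small methyl group on the same nitrogen would fall relative to these two values, and such groups could help separate those differences. Going by these compounds, it also remains open whether a step of this size would persist if an amine or a carboxylic acid were placed elsewhere on the shared core.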